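A few compounds are considered here, and "the series" means these few. Any claim that something is new, unique, unknown or untested is made for them only; others in the source may bear on it.

Compound 1 `CCN(Cc1ccc(Br)cc1)c1cccc(C(=O)N2CCc3ccc(OS(N)(=O)=O)cc3C2)c1`: 84.5%
Compound 2 `CCN(Cc1ccccn1)c1ccc(C(=O)N2CCc3ccc(OS(N)(=O)=O)cc3C2)cc1`: 87.7%
Compound 3 `CCN(Cc1ccc(F)cc1)c1cccc(C(=O)N2CCc3ccc(OS(N)(=O)=O)cc3C2)c1`: 66.5%

In an assay on HEK293 cells for inhibition of Steryl-sulfatase (Homo sapiens), tested at 1 uM (a lower number here means a weaker effect, a higher number a stronger effect of the compound at the concentration tested), compound 2 stands highest of the three numbers, with compound 1 within the scatter of it and compound 3 beyond it. Going by the values given here, the only step between measured compounds, a number 18 percentage points lower from compound 1 to compound 3 (beyond the scatter), concerns a halogen on an aromatic carbon and nothing else. Compound 4 `CCCN(CCC)c1ccc(C(=O)N2CCc3ccc(OS(N)(=O)=O)cc3C2)cc1` differs from compound 2 at the amine: dipropylamino in place of ethyl((pyridin-2-yl)methyl)amino on an aromatic carbon. Among the compounds with values here, no measured step alters this group, so the halogen step gives no direct guide; it shows only that a change in this region can move the read-out by a modest amount. Compound 4 is therefore expected to lie somewhat lower than compound 2, a number 12.7 percentage points lower from compound 2 to compound 4 (beyond the scatter). The estimate for compound 4 is 75%, between 55% and 92%.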

Compound 4, a percentage reported as inhibition, at one concentration (the size of the read-out at that concentration, not a potency): 84.7%
Estimate against measurement, compound 4: 9.7 percentage points below, within the range that was stated.
By their numbers in this assay, from the lowest: compound 3; then compounds 1, 4 and 2 (each within the scatter of the next).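

Dipropylamino in place of ethyl((pyridin-2-yl)methyl)amino gives a number 3 percentage points lower from compound 2 to compound 4 (within the scatter) in this assay. At this place, on an aromatic carbon para to a large group, the open-chain amine without a ring therefore reads the same as the amine carrying the six-membered aromatic ring with a hetero atom, within the scatter. Nothing measured here bears on why the two read alike.

Going by these compounds, how a plain amino group, a morpholine or a longer chain such as dibutylamino would read at this place remains open.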